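The source may hold more compounds than are shown below. What is called first, only, known or untested is meant among the compounds shown, and "the series" means these compounds.

Series in a physicochemical assay for lipophilicity; on this read-out higher numbers stand for higher lipophilicity and lower numbers for lower lipophilicity:
- compound 1 `C[C@H]1CC[C@@H]2[C@@H](OC(=O)[C@]23CC(c2ccc(Br)cc2)N(c2ccccc2)O3)[C@]2(C)C(=O)C=C[C@@]12O` gives 4
- compound 2 `C[C@H]1CC[C@@H]2[C@@H](OC(=O)[C@]23CC(c2c(Cl)cccc2Cl)N(c2ccccc2)O3)[C@]2(C)C(=O)C=C[C@@]12O` gives 4.45
- compound 3 `C[C@H]1CC[C@@H]2[C@@H](OC(=O)[C@]23CC(c2c(F)cccc2F)N(c2ccccc2)O3)[C@]2(C)C(=O)C=C[C@@]12O` gives 3.42

Compound 3 holds the lowest of the three numbers, and compound 1 is its nearest neighbour. The next compound is compound 4 `C[C@H]1CC[C@@H]2[C@@H](OC(=O)[C@]23CC(c2ccccc2F)N(c2ccccc2)O3)[C@]2(C)C(=O)C=C[C@@]12O`, not yet measured in this assay. The change is hydrogen in place of fluoro on an aromatic carbon, which turns 2,6-difluorophenyl into 2-fluorophenyl.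

For the measured compounds named here, no measured pair makes this exact exchange, so the evidence is indirect. The closest step is a number 1.03 log units lower from compound 2 to compound 3 (beyond the scatter), which is large but exchanges one pair of halogens for another and removes none. The steps of a number 0.58 log units lower from compound 1 to compound 3 (beyond the scatter) and a number 0.45 log units higher from compound 1 to compound 2 (beyond the scatter) are modest and also change the aryl pattern as a whole. Only a single fluoro leaves here, so a much smaller step than any of these is expected, and none beyond the scatter is the working expectation. The expected outcome is a number 0.07 log units lower from compound 3 to compound 4 (within the scatter) as an estimate. The estimated value for compound 4 is 3.35, with an expected range from 3 to 3.7.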

Compound 4, partition coefficient: 3.35
Compound 4: middle estimate and measured number agree at the digits printed, and the stated range covers the measured number.
By their numbers in this assay, from the lowest: compounds 4 and 3 (each within the scatter of the next); then compound 1; then compound 2.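

In this assay the series now has a single-atom exchange on this aromatic carbon, and the hydrogen in place of fluoro gives a number 0.07 log units lower from compound 3 to compound 4 (within the scatter) so that 2-fluorophenyl and 2,6-difluorophenyl are not separated on this read-out. The exchanges of the whole aryl group remain the ones that separate compounds, with a number 1.10 log units lower from compound 2 to compound 4 (beyond the scatter) for 2-fluorophenyl in place of 2,6-dichlorophenyl and a number 0.65 log units lower from compound 1 to compound 4 (beyond the scatter) for 2-fluorophenyl in place of 4-bromophenyl, so one fluoro more or less on this ring does not reproduce the gaps seen between the different halogen patterns. No measurement among these compounds accounts for any of these steps.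

Open, from the compounds shown here alone, is what plain phenyl, with no halogen left on this ring, would give, which would show whether the loss of the remaining fluoro is as small as the loss of the first. Also open, going by these compounds, is whether hydrogen in place of chloro, linking 2,6-dichlorophenyl to 2-chlorophenyl, stays as small as the fluoro exchange, and how an aryl ring bearing an amine or a carboxylic acid would read in this assay on the same core.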